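The source may report more compounds than this note shows. Statements on the series, on what has been measured and on what is new or still open speak of the compounds shown alone.

The shared core appears in compound 1 `N[C@H]1CC[C@H](Nc2c(C(=O)NCc3ccc(F)cc3)nc(N3CCCCC3)c3cccnc23)CC1`, compound 2 `N[C@H]1CC[C@H](Nc2c(C(=O)NCc3ccc(Oc4ccccc4)cc3)nc(Br)c3cccnc23)CC1`, compound 3 `COC(=O)c1nc(Br)c2cccnc2c1N[C@H]1CC[C@H](N)CC1` and the still unmeasured compound 4 `N[C@H]1CC[C@H](Nc2c(C(=O)NC3CCCCC3)nc(Br)c3cccnc23)CC1`. In a functional assay on MCF7 cells (Homo sapiens) for cytotoxicity, read by MTT assay, with a stated time of 72 h (on this read-out lower numbers stand for stronger inhibition and higher numbers for weaker inhibition), compound 1 gives 5000 nM. In this assay compound 2 gives 7900 nM. Compound 3 reaches only a limit in this assay, recorded as > 20000 nM, which is not a number but the edge of what the assay reports; this is the limit of > 20000 nM in this assay, at which 1 of the 3 values shown sits. Compound 3 thus stands apart from the two numbered values, with no figure of its own.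

The step to compound 4 is cyclohexylamino in place of methoxy on a carbonyl carbon. Among the measured compounds shown here, no pair of measured compounds isolates this change, so its size cannot be read directly. Compound 1 carries a carbamoyl group at that carbonyl and gives 5000 nM, and compound 2 carries a carbamoyl group there as well and gives 7900 nM; both are measured numbers. Compound 3, with methoxycarbonyl at that carbonyl, reaches only a limit. On that ground the move from methoxycarbonyl to cyclohexylcarbamoyl is expected to bring compound 4 within the measurable range, toward stronger inhibition. The step of an at least 2.5-fold lower number from compound 3 to compound 4 (0.39 log units; beyond the scatter) is expected to exceed the scatter. Compound 4 is estimated at 8000 nM in this assay, within a range from 3000 nM to 20000 nM.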

Compound 4, half-maximal inhibitory concentration: 5200 nM
The estimate for compound 4 lay 1.5-fold (0.19 log units) above the measured number; low and high end bracket the measured number.
By their numbers in this assay, from the lowest: compounds 1, 4 and 2 (each within the scatter of the next). At a limit, above all of these: compound 3.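

In this assay, cyclohexylamino in place of methoxy on a carbonyl carbon gives an at least 3.8-fold lower number from compound 3 to compound 4 (0.58 log units; beyond the scatter), the first change in a single place that can be read among these compounds. With everything else in the molecule left as it is, the group on this carbonyl carbon alone carries the compound from a limit to a measured number, by a step beyond the scatter. Compound 3 stands at a limit and not at a number, so the step is a bound and its full size cannot be read: the limit of > 20000 nM in this assay, at which 1 of the 4 values shown sits.

The cyclohexylamino group brings in its ring and the amide hydrogen together, so the compounds shown cannot tell which of the two goes with the step. From the compounds shown here alone, a plain amino group, a dimethylamino group, an open chain such as n-butylamino, or a carboxylic acid on the same carbonyl carbon would separate these parts, and how each of them would stand in this assay remains open.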